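This account rests on a few compounds, and the source may have more. Where it says the series, first, only, none or still open, it means among the compounds named here.

Of the compounds shown here, three of one series have been measured in an assay on membranes from brain for binding affinity to Lysophosphatidylserine lipase ABHD12 (Mus musculus), read by fluorescence, with a stated time of 20 min; a lower number here means a stronger inhibitor, a higher number a weaker inhibitor. Compound 1 `FC(F)(F)c1cnc(N2CCC(NC(=S)Nc3cccnc3)CC2)c(Cl)c1` gives 1100 nM. Compound 3 `Cc1cnc(N2CCC(NC(=S)Nc3cccnc3)CC2)c(Cl)c1` gives 3100 nM, the highest of the two numbers recorded, and the step of a 2.8-fold higher number from compound 1 to compound 3 (0.45 log units; beyond the scatter) sets it apart from compound 1. Compound 2 `COc1ccnc(N2CCC(NC(=S)Nc3cccnc3)CC2)c1` reaches only a limit of the assay, > 5000 nM, so it carries no number; this limit is the limit of > 5000 nM in this assay, at which 1 of the 3 values shown sits. The step of an at least 1.6-fold lower number from compound 2 to compound 3 (0.20 log units; that floor lies within the scatter) can therefore be read only as a floor.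

Compound 4 `S=C(Nc1cccnc1)NC1CCN(c2ncccc2Cl)CC1` differs from compound 3 by hydrogen in place of methyl on an aromatic carbon. Among the compounds with values here, no measured pair shows a methyl removed in this way, so the nearest guide is the change at the same aromatic carbon in the step of a 2.8-fold higher number from compound 1 to compound 3 (0.45 log units; beyond the scatter), a modest step. Swapping a small group for no group at that position is a smaller change than the trifluoromethyl-to-methyl swap, so the expected step of a 1.3-fold higher number from compound 3 to compound 4 (0.11 log units; within the scatter) in this assay is small, slightly toward a higher number, and may not exceed the scatter. Compound 4 is thus estimated to give 4000 nM in this assay, with a plausible range from 1800 nM to 9000 nM.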

Compound 4, half-maximal inhibitory concentration: > 5000 nM
Compound 4: a limit, no number (the forecaster's own chance of this, stated with the estimate: 30%); at least 1.2-fold (0.09 log units) between middle value and limit.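

In this assay compound 4 gives > 5000 nM, which is a limit of the assay and not a number: the limit of > 5000 nM in this assay, at which 2 of the 4 values shown sit. Comparing the ends of the series at this aromatic carbon shows an at least 4.5-fold higher number from compound 1 to compound 4 (0.65 log units; beyond the scatter), so hydrogen there clearly gives a weaker result than trifluoromethyl, and the choice of group at this position matters. Taking away only the methyl gives an at least 1.6-fold higher number from compound 3 to compound 4 (0.20 log units; that floor lies within the scatter), so the new result does not establish whether methyl offers any real gain over hydrogen at this position.

Going by these compounds, the step between compound 2 and compound 4 joins two limits and cannot be read, and the true number for compound 4 remains unknown. On these data alone, it also remains open how other groups at this carbon would compare with trifluoromethyl, for example a nitrile, an ethyl group or a bromine atom, and whether any of them would give a lower number than compound 1.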